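The source may hold more compounds than are shown below. What is called first, only, known or untested is meant among the compounds shown, and "the series" means these compounds.

Measured so far in a functional assay on MCF7 cells (Homo sapiens) for antiproliferative activity, read by MTT assay, with a stated time of 48 h; a lower number here means a stronger inhibitor, a higher number a weaker inhibitor:
- compound 1, `Cc1ccc2nc(Nc3nc(Nc4ccc(S(N)(=O)=O)cc4)ncc3F)sc2c1`, gives 24500 nM.
- compound 2, `Cc1ccc2nc(Nc3nc(Nc4ccc(S(C)(=O)=O)cc4)ncc3F)sc2c1`, gives > 50000 nM, which is a limit of this assay and not a number.
- compound 3, `COc1cccc(Nc2ncc(C)c(Nc3nc4ccccc4s3)n2)c1`, gives > 50000 nM, again a limit of this assay.

Compound 2 thus stands at the limit of this assay, where two of the three values sit (the limit of > 50000 nM in this assay, at which 2 of the 3 values shown sit). Within the data shown here, the only step between measured compounds, an at least 2.0-fold higher number from compound 1 to compound 2 (0.30 log units; that floor lies within the scatter), concerns a methyl in place of an amino on a sulfonyl sulfur and reaches only the limit.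

Compound 4, `COc1ccc2nc(Nc3nc(Nc4ccc(S(C)(=O)=O)cc4)ncc3F)sc2c1`, differs from compound 2 by methoxy in place of methyl on an aromatic carbon. Among the measured compounds shown here, no measured step touches this position or this exchange, so there is no measured guide to its size or direction. With compound 2 at the limit, compound 4 is expected to remain there or near it. The step that the limit leaves unreadable from compound 2 to compound 4 is therefore expected to be small. Compound 4 is estimated at 60000 nM, within a range from 25000 nM to 200000 nM.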

Compound 4, half-maximal inhibitory concentration: 5850 nM
Estimate against measurement, compound 4: 10-fold (1.01 log units) above; measured number below the stated range.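

Compound 4 shows that this aromatic carbon of the fused system matters in this assay, where methoxy in place of methyl gives an at least 8.5-fold lower number from compound 2 to compound 4 (0.93 log units; beyond the scatter) and brings the series off the limit. Among these compounds, the earlier compounds showed a change only on the sulfonyl sulfur, so this is the only measured evidence that an exchange at this position can shift the read-out, and it does so with the methyl on the sulfonyl sulfur kept in place. Compound 2 gives > 50000 nM, which is a limit and not a number, so the step is only a floor and its full size cannot be read: the limit of > 50000 nM in this assay, at which 2 of the 4 values shown sit.

Going by these compounds, whether the same exchange would carry over to compound 1, with its amino on the sulfonyl sulfur, stays open. So does how an ethoxy, a hydroxyl or a chlorine on this aromatic carbon would compare with methoxy.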